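Ring for chain: returning toward the acyclic hydrazone

The compounds below may be only part of what the source reports. "The series", "measured", "known", "first", "only" and "open" are said of these compounds alone.

Measured compounds:
compound 1, `CCOC(=O)C1=C(NN=C(C(C)=O)C(C)=O)Nc2[nH]nc(C)c2C1c1ccc(N(C)C)cc1`, 9740 nM
compound 2, `CCOC(=O)C1=C(N/C=N/c2nnc(S(N)(=O)=O)s2)Nc2[nH]nc(C)c2C1c1ccc(N(C)C)cc1`, 34500 nM
compound 3, `CCOC(=O)C1=C(N/C=N/c2ccc(C)cc2)Nc2[nH]nc(C)c2C1c1ccc(N(C)C)cc1`, 50500 nM

All three were tested in a functional assay on MCF7 cells (Homo sapiens) for inhibition, read by MTT assay, with a stated time of 48 h; a lower number here means a stronger inhibitor, a higher number a weaker inhibitor. On these numbers compound 2 stands second highest of three: its nearest neighbour is compound 3, with a 1.5-fold higher number from compound 2 to compound 3 (0.17 log units; within the scatter), and its furthest is compound 1, with a 3.5-fold higher number from compound 1 to compound 2 (0.55 log units; beyond the scatter).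

Compound 4, `CCOC(=O)C1=C(N/N=C(/C(C)=O)C(=O)OCC)Nc2[nH]nc(C)c2C1c1ccc(N(C)C)cc1`, has not yet been measured. Relative to compound 2 it carries a group of 10 heavy atoms (6 carbon, 1 nitrogen, 3 oxygen; no ring) in place of a group of 11 heavy atoms (3 carbon, 4 nitrogen, 2 oxygen, 2 sulfur; one five-membered aromatic ring with 3 hetero atoms), on an amine nitrogen.

Among the measured compounds shown here, the step that bears on this change is the one from compound 1 to compound 2, a 3.5-fold higher number from compound 1 to compound 2 (0.55 log units; beyond the scatter), where a five-membered aromatic ring replaced an acyclic group of carbon, nitrogen and oxygen on the same amine nitrogen. Compound 4 undoes that kind of change: the ring leaves and an acyclic group with carbonyls enters, much as in compound 1. The step from compound 1 to compound 3, a 5.2-fold higher number from compound 1 to compound 3 (0.71 log units; beyond the scatter), also gave a higher number when a ring replaced the acyclic group. The expectation for compound 4 is therefore a lower number than compound 2, a step roughly the reverse of compound 1 to compound 2, namely a 2.9-fold lower number from compound 2 to compound 4 (0.46 log units; beyond the scatter). The estimate for compound 4 in this assay is 12000 nM, with a range from 5000 nM to 30000 nM.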

Compound 4, half-maximal inhibitory concentration: > 100000 nM
Compound 4: a limit, no number; the forecaster's own chance of this, stated with the estimate: 5%; at least 8.3-fold (0.92 log units) between middle value and limit.
By their numbers in this assay, from the lowest: compound 1; then compounds 2 and 3 (each within the scatter of the next). At a limit, above all of these: compound 4.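

In this assay compound 4 gives no number but a limit, and that limit is the only one among the compounds shown: the limit of > 100000 nM in this assay, at which 1 of the 4 values shown sits. An open chain on the amine nitrogen therefore does not by itself give the lower number, since exchanging one acyclic group for another, the group of 10 heavy atoms for the group of 8 heavy atoms, gives the largest step here, an at least 10-fold higher number from compound 1 to compound 4 (1.01 log units; beyond the scatter), so that the two acyclic compounds lie at opposite ends of the series. Removing the ring of compound 2 does not reverse the step from compound 1 to compound 2, as an at least 2.8-fold higher number from compound 2 to compound 4 (0.46 log units; beyond the scatter) runs in the same direction as that step, while an at least 1.9-fold higher number from compound 3 to compound 4 (0.29 log units; that floor lies within the scatter) has a floor too small to set compound 4 apart from compound 3.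

Going by these compounds, how far the true value of compound 4 lies past its limit stays unknown, so the size of these steps has only a floor. The compounds shown also leave open whether the loss follows the ethyl ester itself, which an amide or a carboxylic acid in its place could test.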